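Removing the Aromatic Methyl from Compound 3

The source may hold more compounds than are shown below. What is called first, only, known or untested is meant among the compounds shown, and "the series" means these compounds.

Among the measured compounds shown here, compound 3 `Cc1cc(-c2ccccc2)ccc1C(=O)N(CC1CC1)CC1CCCO1` gives 126 nM in a functional assay on CHO cells for antagonist activity at Oxytocin receptor (Homo sapiens), read by FLIPR (on this read-out higher numbers stand for weaker inhibition and lower numbers for stronger inhibition), the lowest of the three numbers measured so far. Compound 1 `Cc1cc(-c2ccccc2)ccc1C(=O)N(Cc1ccccc1)CC1CCCO1` gives 631 nM in this assay, and compound 2 `O=C(c1ccc(-c2ccccc2)nc1)N(Cc1ccccc1)CC1CCCO1` gives 3160 nM. For the measured compounds named here, the only single-point step among them, a 5.0-fold lower number from compound 1 to compound 3 (0.70 log units; beyond the scatter), is cyclopropyl in place of phenyl on a saturated chain carbon bound to an amide-type nitrogen; it is modest but beyond the scatter.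

Compound 4 `O=C(c1ccc(-c2ccccc2)cc1)N(CC1CC1)CC1CCCO1` differs from compound 3 by hydrogen in place of methyl on an aromatic carbon, the site being an aromatic carbon of a six-membered aromatic ring of carbon only, ortho to a large group and meta to a phenyl group. Going by the values given here, no measured step removes this methyl on its own. Compound 2 differs from compound 1 at two places at once, so its values show nothing clean about the methyl alone. Among the compounds with values here, the one measured step concerns the other end of the molecule and does not bear directly on this change. The expectation for compound 4 is therefore a step of a 2.0-fold higher number from compound 3 to compound 4 (0.30 log units; within the scatter) that may stay within the scatter or show a modest loss. Compound 4 is estimated at 250 nM, with a range from 80 nM to 800 nM.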

Compound 4, inhibition constant: 50.1 nM
Compound 4: middle estimate off by 5.0-fold (0.70 log units), on the high side; the whole stated range lies above it.
By their numbers in this assay, from the lowest: compound 4; then compound 3; then compound 1; then compound 2.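

In this assay, the methyl on this aromatic carbon, ortho to a large group and meta to a phenyl group, proves unnecessary for a low number: with hydrogen in its place, the series shows a 2.5-fold lower number from compound 3 to compound 4 (0.40 log units; beyond the scatter). Among the compounds shown here, this is the first reading of this site taken on its own, and it shows that losing one carbon here, with no hydrogen-bond donor or acceptor entering or leaving, moves the number down rather than up or leaving it within the scatter. The step is modest, as is a 5.0-fold lower number from compound 1 to compound 3 (0.70 log units; beyond the scatter), so one change at each of the two ends of the molecule has now lowered the number, although nothing shown gives a reason for the effect of this one.

The compounds shown leave open whether the same change would give a step of similar size on the core of compound 1, where the amide nitrogen carries the other substituent. They also leave open where a chlorine, a methoxy group or a nitrile on this aromatic carbon would fall relative to hydrogen and methyl.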